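Urea series on the melanin-concentrating hormone receptor: a sulfonyl variant

A few compounds are considered here, and "the series" means these few. Any claim that something is new, unique, unknown or untested is made for them only; others in the source may bear on it.

Measured compounds:
compound 1 `O=C(NC1CCN(Cc2ccn(-c3ccc(C(F)(F)F)cc3)c2)CC1)N1CCCC1Cc1cccnc1` gives 26 nM
compound 2 `O=C(NCC1(O)CCCCC1)NC1CCN(Cc2ccn(-c3ccc(C(F)(F)F)cc3)c2)CC1` gives 44 nM

Both were run in an assay on HEK293 cells for displacement of a labelled ligand from melanin-concentrating hormone receptor 1 (Homo sapiens); on this read-out lower numbers stand for stronger inhibition and higher numbers for weaker inhibition. Compound 2 has the highest of the two numbers, but the step of a 1.7-fold higher number from compound 1 to compound 2 (0.23 log units; within the scatter) is within the scatter, so no order between them can be read from this. Compound 3 `O=C(NC1CCN(Cc2ccn(-c3ccc(C(F)(F)F)cc3)c2)CC1)NS(=O)(=O)c1ccc(F)cc1` is not yet measured. It differs from compound 2 by (4-fluorophenyl)sulfonyl in place of (1-hydroxycyclohexyl)methyl on an amide-type nitrogen, the same difference read one bond further out being ((1-hydroxycyclohexyl)methyl)amino to ((4-fluorophenyl)sulfonyl)amino. For the measured compounds named here, no measured step touches this position with a group of this kind, and the only step recorded, from compound 1 to compound 2, was within the scatter. The expectation for compound 3 therefore rests on compound 2 alone and is wide: a step of a 2.3-fold higher number from compound 2 to compound 3 (0.36 log units; beyond the scatter) is estimated, leaning to a weaker number. Compound 3 is expected to come in at about 100 nM, between 25 nM and 400 nM.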

Compound 3, half-maximal inhibitory concentration: 617 nM
The estimate for compound 3 lay 6.2-fold (0.79 log units) below the measured number, outside the stated range (above it).
By their numbers in this assay, from the lowest: compounds 1 and 2 (each within the scatter of the next); then compound 3.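

In this assay this place on an amide-type nitrogen proves sensitive to what it carries: (4-fluorophenyl)sulfonyl in place of (1-hydroxycyclohexyl)methyl gives a 14-fold higher number from compound 2 to compound 3 (1.15 log units; beyond the scatter), a large step, whereas the earlier exchange on the carbonyl carbon stayed within the scatter. Set against 2-((pyridin-3-yl)methyl)pyrrolidin-1-yl, ((4-fluorophenyl)sulfonyl)amino on the carbonyl carbon gives a 24-fold higher number from compound 1 to compound 3 (1.38 log units; beyond the scatter), also large, so the sulfonyl compound stands clearly apart from both earlier compounds. No supporting data bear on the reason for these steps.

The compounds shown do not separate the contribution of the sulfonyl link from that of the 4-fluorophenyl ring. A methylsulfonyl group or a 4-fluorobenzoyl group on the same nitrogen would bear on that question.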